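The compounds below may be only part of what the source reports. "The series", "measured", "known", "first", "only" and "open" are said of these compounds alone.

Measured so far:
compound 1 `COc1ccccc1C(C)NC(=O)COc1cc(C(F)(F)F)c2c(-c3ccccc3)nn(C)c2n1` — 158 nM
compound 2 `C[C@H](NC(=O)COc1cc(C(F)(F)F)c2c(-c3ccccc3)n[nH]c2n1)c1ccccc1` — 43 nM

In a functional assay on isolated protein for antagonist activity at Orexin receptor type 2 (Homo sapiens), read by fluorescence, FLIPR and calcium flux, with a stated time of 1 h (a higher number here means a weaker inhibitor, a lower number a stronger inhibitor), compound 1 gives 158 nM, the higher of the two numbers shown, while compound 2 gives 43 nM. Compound 3 `Cc1nn(C)c(C)c1[C@H](C)NC(=O)COc1cc(C(F)(F)F)c2c(-c3ccccc3)nn(C)c2n1` has not yet been measured; it differs from compound 1 by the change (1-(1,3,5-trimethyl-1H-pyrazol-4-yl)ethyl in place of 1-(2-methoxyphenyl)ethyl on an amide-type nitrogen). Among the measured compounds shown here, no measured pair shows this exact change, so the direction is uncertain. The expectation is that the change from compound 1 to compound 3 gives a 1.6-fold higher number from compound 1 to compound 3 (0.20 log units; within the scatter), a modest weakening within a wide range. Compound 3 is therefore estimated at 250 nM, with a range from 80 nM to 800 nM.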

Compound 3, inhibition constant: 10 nM
The estimate for compound 3 lay 25-fold (1.40 log units) above the measured number, and the stated range ends above it.
By their numbers in this assay, from the lowest: compound 3; then compound 2; then compound 1.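

In this assay the group on the amide-type nitrogen has a large effect: 1-(1,3,5-trimethyl-1H-pyrazol-4-yl)ethyl in place of 1-(2-methoxyphenyl)ethyl gives a 16-fold lower number from compound 1 to compound 3 (1.20 log units; beyond the scatter) on an otherwise unchanged structure. A five-membered aromatic ring with 2 hetero atoms can therefore stand at this position in place of a six-membered aromatic ring of carbon only, without any loss. No available data explain why the number falls. As far as these compounds go, the step changes the ring, its substituents and the defined stereocentre together, so their separate shares stay unknown. From the compounds shown here alone, how a pyridine ring or a pyrazole without methyl groups would behave here remains open.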